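Cyclohexyl in place of 4-nitrophenyl: working notes

A few compounds are considered here, and "the series" means these few. Any claim that something is new, unique, unknown or untested is made for them only; others in the source may bear on it.

In a functional assay on HL-60 cells (Homo sapiens) for cytotoxicity, read by WST assay, with a stated time of 48 h (on this read-out lower numbers stand for stronger inhibition and higher numbers for weaker inhibition), compound 1 (`O[C@@H](c1ccccc1)[C@H]1CO[C@H](c2ccccc2)[C@@H](C/C=C/c2cccc(F)c2)C1`) gives 9170 nM and compound 2 (`Cc1ccc(/C=C/C[C@H]2C[C@@H]([C@@H](O)c3ccccc3)CO[C@@H]2c2ccccc2)cc1C`) gives 9880 nM while compound 3 (`O=[N+]([O-])c1ccc(/C=C/C[C@H]2C[C@@H]([C@@H](O)c3ccccc3)CO[C@@H]2c2ccccc2)cc1`) gives 4880 nM and so has the lowest of the three numbers. That standing is clear on one side only, with a modest step (a 2.0-fold lower number from compound 2 to compound 3 (0.31 log units; beyond the scatter)) and a step within the scatter on the other (a 1.9-fold lower number from compound 1 to compound 3 (0.27 log units; within the scatter)).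

Compound 4 (`O[C@@H](c1ccccc1)[C@H]1CO[C@H](c2ccccc2)[C@@H](C/C=C/C2CCCCC2)C1`) differs from compound 3 at a single place (cyclohexyl in place of 4-nitrophenyl on a double-bonded chain carbon bound to a double-bonded chain carbon). Within the data shown here, all three measured compounds carry a phenyl group there, so no measured step covers a non-aromatic ring, and the bearing of these steps is indirect. Among the measured compounds shown here, exchanging 3-fluorophenyl for 3,4-dimethylphenyl changed little (a 1.1-fold higher number from compound 1 to compound 2 (0.03 log units; within the scatter)), and only the step to 4-nitrophenyl from 3,4-dimethylphenyl passed the scatter, and only just. The step expected in this assay is therefore small and upward, and may stay within the scatter (a 1.7-fold higher number from compound 3 to compound 4 (0.24 log units; within the scatter)). For compound 4 the estimated value is 8500 nM (expected range 4000 nM to 18000 nM).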

Compound 4, half-maximal inhibitory concentration: 6260 nM
For compound 4 the middle estimate is 1.4-fold (0.13 log units) above the measured one; measured number inside the range.
By their numbers in this assay, from the lowest: compounds 3, 4, 1 and 2 (each within the scatter of the next, the first and the last beyond it).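

In this assay, cyclohexyl is the only non-aromatic ring shown on a double-bonded chain carbon bound to a double-bonded chain carbon, and it stays within the scatter of all three phenyl-bearing compounds (a 1.3-fold higher number from compound 3 to compound 4 (0.11 log units; within the scatter); a 1.6-fold lower number from compound 2 to compound 4 (0.20 log units; within the scatter); a 1.5-fold lower number from compound 1 to compound 4 (0.17 log units; within the scatter)). An aromatic ring at this place is therefore not needed for a number in this range, and exchanging 4-nitrophenyl for a ring of carbon only, without hydrogen-bond acceptors, produces no step beyond the scatter. Nothing available explains why these numbers stay so close.

The compounds shown leave open how an amine, such as a piperidine ring, a carboxylic acid or a longer alkyl chain would read at this place. They also leave open whether any group here can move the number well beyond the scatter of this series.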